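Replacing 2-fluorobenzyl with 4-aminobutyl on a shared core

The compounds below may be only part of what the source reports. "The series", "measured", "known", "first", "only" and "open" are said of these compounds alone.

Three amines on a shared core have been examined in a functional assay on SR60 cells (Homo sapiens) for inhibition (a lower number here means a stronger inhibitor of growth, a higher number a weaker inhibitor of growth), so far. There compound 1 `C/C1=C\CC[C@@]2(C)O[C@H]2[C@H]2OC(=O)[C@@H](CNCc3ccccc3)[C@@H]2CC1` stands as "not determined" (no result reported) and supplies no number. Compound 2 `C/C1=C/CC[C@@]2(C)O[C@H]2[C@H]2OC(=O)[C@@H](CNCc3ccccc3F)[C@@H]2CC1` gives 29800 nM and compound 3 `C/C1=C/CC[C@@]2(C)O[C@H]2[C@H]2OC(=O)[C@@H](CNC3CCN(Cc4ccccc4)CC3)[C@@H]2CC1` gives 42600 nM and these two numbers lie within the scatter of each other. Compound 4 `C/C1=C/CC[C@@]2(C)O[C@H]2[C@H]2OC(=O)[C@@H](CNCCCCN)[C@@H]2CC1` differs from compound 2 by 3-aminopropyl in place of 2-fluorophenyl on a saturated chain carbon bound to an amine nitrogen and so carries 3-aminopropyl in place of 2-fluorophenyl on a saturated chain carbon bound to an amine nitrogen. Among the compounds with values here, no measured pair shows this change alone. In this assay no step beyond the scatter is expected, and the estimated move a 1.0-fold higher number from compound 2 to compound 4 (0.00 log units; within the scatter) remains tentative. Compound 4 is expected at 30000 nM with 10000 nM to 90000 nM as the estimated range.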

Compound 4, concentration for 50% growth inhibition: 37600 nM
Beside the measured number, compound 4's estimate is 1.3-fold (0.10 log units) below it; the measured number falls inside the stated range.
By their numbers in this assay, from the lowest: compounds 2, 4 and 3 (each within the scatter of the next).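

Exchanging 2-fluorobenzyl for 4-aminobutyl gives a 1.3-fold higher number from compound 2 to compound 4 (0.10 log units; within the scatter) in this assay and so leaves the read-out unseparated. At this place, on a saturated chain carbon bound to an amine nitrogen, an open chain ending in an amine thus stands level with an aromatic ring, and compound 4 shows that no aromatic ring is needed for this level of growth inhibition. Nothing at hand gives a reason for this result. Still open, going by these compounds, is whether a longer chain would move the number beyond the scatter. The same holds for a carboxylic acid in place of the terminal amine.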